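The source may hold more compounds than are shown below. What is called first, only, known or untested is meant among the compounds shown, and "the series" means these compounds.

In a functional assay on HCT-116 cells (Homo sapiens) for antiproliferative activity (on this read-out higher numbers stand for weaker inhibition and lower numbers for stronger inhibition), compound 1 `COc1ccc(-c2snnc2-c2cc(OC)c(OC)c(OC)c2)cc1[N+](=O)[O-]` gives 30.2 nM, and compound 2 `COc1cc(-c2nnsc2-c2ccc(Cl)cc2)cc(OC)c1OC` gives 18.5 nM, so these two values lie within the scatter of each other. Compound 3 `COc1cc(-c2nnsc2-c2ccc(F)cc2)cc(OC)c1OC` is reported only as a limit, > 1000 nM. For the measured compounds named here, the single measured step, an at least 54-fold higher number from compound 2 to compound 3 (1.73 log units; beyond the scatter), is large and swaps fluoro in place of chloro on an aromatic carbon. Compound 4 `COc1ccc(-c2snnc2-c2cc(OC)c(OC)c(OC)c2)cc1N` instead carries amino in place of nitro on an aromatic carbon. Going by the values given here, no measured step covers this change directly, although the one above shows that a single swap can matter greatly. The expected result in this assay is therefore no change beyond the scatter, with wide uncertainty: a 1.2-fold lower number from compound 1 to compound 4 (0.08 log units; within the scatter). Compound 4 is estimated at 25 nM, with an expected range of 5 nM to 200 nM.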

Compound 4, half-maximal inhibitory concentration: 3.7 nM
Estimate against measurement, compound 4: 6.8-fold (0.83 log units) above, and the stated range ends above it.
By their numbers in this assay, from the lowest: compound 4; then compounds 2 and 1 (each within the scatter of the next). At a limit, above all of these: compound 3.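

In this assay, amino in place of nitro gives an 8.2-fold lower number from compound 1 to compound 4 (0.91 log units; beyond the scatter), so this position, ortho to a methoxy group, responds to its substituent, and nitro is not needed there for compound 4 to reach 3.7 nM. The earlier step between compounds concerned only chloro and fluoro and said nothing about this position. Nothing in the data at hand bears on why the change has this effect.

From the compounds shown here alone, whether a hydroxyl, methylamino or acetamido group would match amino here remains open. So does whether amino would give a similar step on other versions of the core.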